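The compounds below may be only part of what the source reports. "The series", "measured", "known", "first", "only" and "open" are said of these compounds alone.

Compounds measured in a functional assay on the whole organism with Rattus norvegicus as the target, at a dose of 3 mg/kg by the oral route; a lower number here means a weaker effect, a higher number a stronger effect of the compound at the dose given:
compound 1 `CCOc1cc(C(=O)Nc2nn[nH]n2)nc(-c2ccc(N)cc2)c1` gives 62%;
compound 2 `CCCOc1cc(C(=O)Nc2nn[nH]n2)nc(-c2ccc(N)cc2)c1` gives 68%;
compound 3 `O=C(Nc1nn[nH]n1)c1cccc(-c2ccccc2)n1` gives 74%.

Compound 3 stands at the highest of the three numbers. Its nearest neighbour, compound 2, lies within the scatter of it, so the two cannot be ranked against each other; compound 1 lies beyond the scatter, lower than compound 3. Within the data shown here, the only single-place step among the measured compounds is a number 6 percentage points higher from compound 1 to compound 2 (within the scatter), a change on the alkoxy chain that has no counterpart in the move to compound 4 `Nc1ccc(-c2cccc(C(=O)Nc3nn[nH]n3)n2)cc1`.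

Compound 4 differs from compound 3 by amino in place of hydrogen on an aromatic carbon. Among the measured compounds shown here, no measured pair differs by this change alone. Compounds 1 and 2 both carry the same amino group, but each also carries an alkoxy group that compound 3 lacks. For the measured compounds named here, compound 1 gives 62% and compound 2 gives 68%; these two numbers show only that the amino-bearing compounds sit at or somewhat below compound 3, without separating the two changes.

On this basis the step is expected to be small, a number 7 percentage points lower from compound 3 to compound 4 (within the scatter), likely within the scatter and if anything downward. Compound 4 is therefore estimated at 67% in this assay, with a range from 52% to 80%.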

Compound 4, a percentage reported as inhibition, in the whole organism at one dose (the size of the read-out at that dose, not a potency): 81%
Compound 4: the middle estimate sits 14 percentage points below what was measured; the measured number lies above the stated range.
By their numbers in this assay, from the lowest: compounds 1, 2, 3 and 4 (each within the scatter of the next, the first and the last beyond it).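

In this assay, amino in place of hydrogen on an aromatic carbon, para to a large group, can now be read alone as a number 7 percentage points higher from compound 3 to compound 4 (within the scatter), so the change from phenyl to 4-aminophenyl has no effect at this position that can be told apart from the scatter. Among these compounds, with the amino group kept, the alkoxy group can also be read alone for the first time: hydrogen in place of propoxy gives a number 13 percentage points higher from compound 2 to compound 4 (beyond the scatter), and hydrogen in place of ethoxy gives a number 19 percentage points higher from compound 1 to compound 4 (beyond the scatter), so the two alkoxy compounds both stand below the compound that lacks this group, by modest steps. Nothing measured here accounts for either step.

The compounds shown leave open whether a hydroxyl group, a dimethylamino group or a carboxylic acid in the place of the amino group would read any differently. They also leave open what an ethoxy or butoxy group does on the core when no amino group is present, since the effect of the alkoxy group is seen here only alongside amino.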